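Adding an aryl group to a proline sulfonamide

This account rests on a few compounds, and the source may have more. Where it says the series, first, only, none or still open, it means among the compounds named here.

Compound 2 `O=C(O)CCNC(=O)[C@@H]1CCCN1S(=O)(=O)c1cc(Cl)cc(Cl)c1` gives the highest number of the three compounds in an assay on RPMI-8866 cells for inhibition of integrin alpha-4/beta-1 (Homo sapiens) (on this read-out lower numbers stand for stronger inhibition and higher numbers for weaker inhibition), at 1510 nM. Compound 1 `CC(C)[C@H](CC(=O)O)NC(=O)[C@@H]1CCCN1S(=O)(=O)c1cc(Cl)cc(Cl)c1` gives 362 nM, and compound 3 `O=C(O)C[C@@H](NC(=O)[C@@H]1CCN1S(=O)(=O)c1cc(Cl)cc(Cl)c1)c1ccc(Oc2ccccc2)cc1` gives 3.1 nM. Compound 4 `O=C(O)C[C@@H](NC(=O)[C@@H]1CCCN1S(=O)(=O)c1cc(Cl)cc(Cl)c1)c1ccc(OC(F)(F)F)cc1` carries 4-(trifluoromethoxy)phenyl in place of hydrogen on a saturated chain carbon bound to an amide-type nitrogen and a saturated chain carbon. Within the data shown here, the one measured step at that position, a 4.2-fold higher number from compound 1 to compound 2 (0.62 log units; beyond the scatter), shows that taking away even the small isopropyl there weakens inhibition modestly. Among the measured compounds shown here, no step links compound 3 to the others, as its core differs too, but its value shows that a large aromatic group on this carbon can go with a far lower number. A large downward step is therefore expected, a 76-fold lower number from compound 2 to compound 4 (1.88 log units; beyond the scatter). Compound 4 is estimated at 20 nM, with a range from 5 nM to 80 nM.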

Compound 4, half-maximal inhibitory concentration: 2.6 nM
For compound 4 the middle estimate is 7.7-fold (0.89 log units) above the measured one, and the stated range ends above it.
By their numbers in this assay, from the lowest: compounds 4 and 3 (each within the scatter of the next); then compound 1; then compound 2.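

In this assay, the change to 4-(trifluoromethoxy)phenyl gives a 580-fold lower number from compound 2 to compound 4 (2.76 log units; beyond the scatter) and so shows that this carbon can carry a whole aromatic ring on the shared core. The earlier step, a 4.2-fold higher number from compound 1 to compound 2 (0.62 log units; beyond the scatter), revealed only a modest effect of isopropyl, whereas this result shows how much inhibition can change at this position. As far as these compounds go, it remains open how a plain phenyl or a 4-methoxyphenyl would compare here, so the ring and its trifluoromethoxy group cannot yet be told apart. No measurement shown here explains the size of this step.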